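The source may hold more compounds than are shown below. What is called first, only, known or untested is meant among the compounds shown, and "the series" means these compounds.

Of the compounds shown here, three built on one shared core have been measured in an assay on Sf9 cells for inhibition of mitogen-activated protein kinase kinase kinase 14 (Homo sapiens), read by ADP-Glo, with a stated time of 60 min; a higher number here means a weaker inhibitor, a lower number a stronger inhibitor. Compound 1 `Cc1[nH]nc(N)c1-c1ccc2ccccc2c1` gives in this assay only a limit, > 100000 nM. Compound 2 `Cc1cccc(-c2c(N)n[nH]c2C)c1` likewise returns a limit in this assay, > 100000 nM. Compound 3 `Cc1[nH]nc(N)c1-c1cccc(Cl)c1` also sits at a limit in this assay, > 100000 nM. Among the compounds with values here, the single step that can be drawn between measured compounds, a step that the two limits leave unreadable from compound 2 to compound 3, cannot be sized because the limit of > 100000 nM in this assay, at which 3 of the 3 values shown sit, holds both of its ends. Compound 2 therefore stands only at a limit, the same one shown by the two other compounds, and no number places it against them.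

Compound 4 `Cc1[nH]nc(N)c1-c1cccc(OC(F)(F)F)c1` differs from compound 2 by trifluoromethoxy in place of methyl on an aromatic carbon. Within the data shown here, the only measured step that touches this position is the unreadable one from compound 2 to compound 3, so no size or direction of change in this assay can be taken from it. Compound 4 is accordingly expected to stay near the limit, the expected step of a number no higher from compound 2 to compound 4 (the limit leaves the size open) carrying little weight. The value of compound 4 in this assay is estimated at 100000 nM, within 30000 nM to 300000 nM.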

Compound 4, half-maximal inhibitory concentration: > 100000 nM
Compound 4 was reported as a limit (the forecaster's own chance of this, stated with the estimate: 75%); the middle value sits exactly at the limit.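

Neither new step, from compound 2 to compound 4 or from compound 3 to compound 4, can be read, because both ends of each sit at one limit: the limit of > 100000 nM in this assay, at which 4 of the 4 values shown sit.

The compounds shown leave open whether any change on the shared core would give a measurable value in this assay.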